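The compounds below may be only part of what the source reports. "The series", "measured", "known", "first", "only" and "open" are said of these compounds alone.

Of the compounds shown here, two have been measured so far in a functional assay on thoracic aorta (Rattus norvegicus, strain Wistar), with a stated time of 15 min; a higher number here means that more compound is needed for the effect, a lower number that less compound is needed. Compound 1 `CC(NC(=O)N(C)S(=O)(=O)c1ccc(Cl)cc1)c1cc(Br)ccc1OCc1ccccc1` gives 146000 nM. Compound 2 `Cc1ccc(OCc2ccccc2)c(C(C)NC(=O)N(C)S(=O)(=O)c2ccccc2)c1` gives 68200 nM, the lower of the two numbers, meaning that less of compound 2 is needed for the effect. The gap between them lies beyond the usual scatter. Within the data shown here, these two compounds differ in more than one place, and no measured pair isolates a single change. Compound 3 `CC(NC(=O)N(C)S(=O)(=O)c1ccccc1)c1cc(Br)ccc1OCc1ccccc1` is compound 2 with one swap: bromo in place of methyl on an aromatic carbon, para to a benzyloxy group (bromo in place of methyl on an aromatic carbon). Among the measured compounds shown here, the only guide to this swap is that compound 1 also carries a bromo and gives 146000 nM, which points to a small upward step in this assay, one that may not clear the scatter. The expected step is a 1.4-fold higher number from compound 2 to compound 3 (0.14 log units; within the scatter). For compound 3 the estimated value is 95000 nM, with an expected range of 45000 nM to 190000 nM.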

Compound 3, half-maximal effective concentration: 60300 nM
Estimate against measurement, compound 3: 1.6-fold (0.20 log units) above; the measured number falls inside the stated range.
By their numbers in this assay, from the lowest: compounds 3 and 2 (each within the scatter of the next); then compound 1.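

In this assay, bromo in place of methyl on an aromatic carbon, para to a benzyloxy group, gives a 1.1-fold lower number from compound 2 to compound 3 (0.05 log units; within the scatter) and so leaves the read-out within the usual scatter, which means that this comparison does not separate the two groups at this position. Compound 3 also provides a single-change comparison with compound 1: hydrogen in place of chloro on an aromatic carbon gives a 2.4-fold lower number from compound 1 to compound 3 (0.38 log units; beyond the scatter) and clears the scatter, although only modestly, with bromo present in both compounds. No outside measurement bears on either step, so the reason for these results stays unknown.

The compounds shown compare only methyl and bromo at the position para to the benzyloxy group, so it remains open whether an amine, a carboxylic acid or a longer chain there would shift the number beyond the scatter. Going by these compounds, the chloro-to-hydrogen comparison is also available only with bromo present, so it is unknown whether the same step would appear with methyl in its place, or how a methoxy group would compare with chloro.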